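This account rests on a few compounds, and the source may have more. Where it says the series, first, only, none or still open, it means among the compounds named here.

Compound 2, `COc1cc(-c2ncnn2-c2cccc(N)c2)cc(OC)c1OC`, is one of three compounds tested in a functional assay on HeLa cells (Homo sapiens) for antiproliferative activity, read by MTT assay, with a stated time of 72 h; on this read-out lower numbers stand for stronger inhibition and higher numbers for weaker inhibition. Its value there is a limit of the assay rather than a number: compound 2 gives > 10000 nM. Compound 3, `CCOc1ccccc1-c1ncnn1-c1cc(OC)c(OC)c(OC)c1`, likewise sits at a limit, giving > 10000 nM. Compound 1, `COc1cc(-n2ncnc2-c2ccc(OC(C)C)cc2)cc(OC)c1OC`, is the only one of the three with a measured number; in this assay compound 1 gives 600 nM. Thus (the limit of > 10000 nM in this assay, at which 2 of the 3 values shown sit), and compound 2 stands at that limit together with compound 3, while the set contains no pair of measured compounds that differ in a single place.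

Compound 4, `COc1cc(-c2ncnn2-c2ccc(N)cc2)cc(OC)c1OC`, has the same atoms as compound 2 joined differently: 4-aminophenyl in place of 3-aminophenyl on an aromatic nitrogen. Among the measured compounds shown here, since no step between measured compounds is available, the size of this change in this assay can only be guessed; a gain beyond the usual scatter is thought plausible, but a value that remains at the limit cannot be ruled out.

Compound 4 is therefore expected to reach about 2500 nM in this assay, within a range of 400 nM to 10000 nM, which would mean an estimated step of an at least 4.0-fold lower number from compound 2 to compound 4 (0.60 log units; beyond the scatter).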

Compound 4, half-maximal inhibitory concentration: > 10000 nM
Compound 4: no number, only a limit (the forecaster's own chance of this, stated with the estimate: 35%); middle value at least 4.0-fold (0.60 log units) away from the limit.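

In this assay compound 4 gives > 10000 nM, which is a limit of the assay and not a number. Compound 2 also sits at a limit, so no step can be read between compound 2 and compound 4: the limit of > 10000 nM in this assay, at which 3 of the 4 values shown sit.

The compounds shown leave open whether 4-aminophenyl in place of 3-aminophenyl changes the read-out at all.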